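The compounds below may be only part of what the source reports. "The series", "measured", "known", "first", "only" and "open" are said of these compounds alone.

Measured compounds:
compound 1, `O=C(NCc1ccc(-c2noc(CCC3CC3)n2)cc1)[C@H]1NCC[C@@H]1O`: 5000 nM
compound 2, `CCCCCCCc1nc(-c2ccc([C@@H](NC(=O)[C@H]3NCC[C@@H]3O)C(C)C)cc2)no1`: 110 nM

In an assay on isolated protein for inhibition of sphingosine kinase 1 (Homo sapiens) (a lower number here means a stronger inhibitor, a higher number a weaker inhibitor), compound 1 stands at the highest of the two numbers; compound 2 sits far lower, beyond the scatter, though it differs from compound 1 in more than one place, so no single step can be read from that pair. Compound 3, `CCCCCCc1nc(-c2ccc(CNC(=O)[C@H]3NCC[C@@H]3O)cc2)no1`, is not yet measured. It differs from compound 1 by one change: butyl in place of cyclopropyl on a saturated chain carbon, two bonds along the chain from an aromatic carbon. For the measured compounds named here, with no one-point step measured, the expected change from compound 1 to compound 3 is a moderate drop in the number, a 3.3-fold lower number from compound 1 to compound 3 (0.52 log units; beyond the scatter). Compound 3 is estimated at 1500 nM, between 400 nM and 6000 nM.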

Compound 3, half-maximal inhibitory concentration: 49 nM
Compound 3: the middle estimate sits 31-fold (1.49 log units) above what was measured; the measured number lies below the stated range.
By their numbers in this assay, from the lowest: compound 3; then compound 2; then compound 1.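

In this assay the swap of cyclopropyl for butyl on a saturated chain carbon, two bonds along the chain from an aromatic carbon, gives a 100-fold lower number from compound 1 to compound 3 (2.01 log units; beyond the scatter) and so shows that this position strongly affects the measured number. The earlier pair differed in more than one place and could not tie a change to this spot. Nothing on hand explains the size of this step.

The compounds shown leave open whether a chain longer than butyl would lower the number further at this place. They also leave open whether a cyclobutyl ring would perform like butyl or like cyclopropyl.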